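A Chloro Substituent on the Anilino Group

The compounds below may be only part of what the source reports. "The series", "measured", "known", "first", "only" and "open" are said of these compounds alone.

Going by the values given here, compound 2 `FC(F)(F)c1ccc(CSc2nc(Nc3ccccc3)c3ccccc3n2)cc1` is one of two compounds measured in a functional assay on HGC-27 cells (Homo sapiens) for cytotoxicity, read by MTT assay, with a stated time of 72 h; a lower number here means a stronger inhibitor, a higher number a weaker inhibitor; in that assay compound 2 gives 26400 nM. Among the compounds with values here, its only neighbour, compound 1 `CCCCCCCCNc1nc(SCc2ccc(C(F)(F)F)cc2)nc2ccccc12`, carries octyl rather than phenyl on a nitrogen on an aromatic ring and gives 13400 nM in this assay. Compound 2 thus stands beside compound 1 rather than apart from it, since the step of a 2.0-fold higher number from compound 1 to compound 2 (0.29 log units; within the scatter) lies within the scatter. Compound 3 `FC(F)(F)c1ccc(CSc2nc(Nc3ccccc3Cl)c3ccccc3n2)cc1` differs from compound 2 by chloro in place of hydrogen on an aromatic carbon. Within the data shown here, no measured step touches this place: the single known step alters the group on the nitrogen, not the anilino part, so it offers no direct guide. With nothing pointing either way, the expectation for compound 3 is a step of a 1.1-fold lower number from compound 2 to compound 3 (0.04 log units; within the scatter), nothing beyond the scatter. Compound 3 is therefore estimated at 24000 nM, within a range from 9000 nM to 65000 nM.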

Compound 3, half-maximal inhibitory concentration: > 50000 nM
Compound 3 ended at the assay's limit; the forecaster's own chance of this, stated with the estimate: 15%; middle value at least 2.0-fold (0.31 log units) from the limit.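

Compound 3 reads only as a limit of the assay, not as a number: the limit of > 50000 nM in this assay, at which 1 of the 3 values shown sits. Going by these compounds, the chloro change itself therefore has only a floor, an at least 1.8-fold higher number from compound 2 to compound 3 (0.27 log units; that floor lies within the scatter), so its true size stays unknown, though it gives no sign of a stronger inhibitor. Going by these compounds alone, the wider swap, 2-chlorophenyl in place of octyl on the nitrogen, reads more clearly: it gives an at least 3.7-fold higher number from compound 1 to compound 3 (0.57 log units; beyond the scatter), the first step here to pass the scatter, where plain phenyl gave a 2.0-fold higher number from compound 1 to compound 2 (0.29 log units; within the scatter).

The compounds shown leave open whether a fluoro, methyl or methoxy group at this same place would give a measurable number. They also leave open how chloro would read elsewhere on the ring, or what an amine there would do.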